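The source may report more compounds than this note shows. Statements on the series, on what has been measured and on what is new or still open speak of the compounds shown alone.

Measured compounds:
- compound 1, `Cc1c(OCCCCOc2cccc(C(=O)O)c2)ccc(C(=O)CC(C)C)c1C`: 18.3%
- compound 2, `Cc1c(OCCCCOc2ccc(C(=O)O)cc2)ccc(C(=O)CC(C)C)c1O`: 51.9%
- compound 3, `COC(=O)c1ccc(OCCCCOc2ccc(C(=O)CC(C)C)c(O)c2C)cc1`: 22.7%

In an assay on HEK293 cells for positive allosteric modulation of metabotropic glutamate receptor 3 (Rattus norvegicus), read by thallium flux, with a stated time of 2.5 min (on this read-out higher numbers stand for larger maximal responses and lower numbers for smaller maximal responses), compound 3 stands second of the three; its value and that of compound 1 lie within the scatter of one another, while compound 2 sits beyond the scatter above it.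

Compound 4, `Cc1c(OCCCCOc2cccc(C(=O)O)c2)ccc(C(=O)CC(C)C)c1O`, is unmeasured. Its change from compound 3 is 3-carboxyphenyl in place of 4-(methoxycarbonyl)phenyl on an oxygen on a saturated carbon. Among the compounds with values here, one measured step bears on this: a number 29.2 percentage points lower from compound 2 to compound 3 (beyond the scatter), which the present change undoes as far as the methyl on the oxygen is concerned, pointing upward. Within the data shown here, the move of the carboxy group to the 3-position has no isolated step; compound 1 carries a 3-carboxyphenyl and gives 18.3%, but it also differs in the core. An upward step of moderate size is expected, a number 13.3 percentage points higher from compound 3 to compound 4 (beyond the scatter), tempered by that uncertainty. Compound 4 is estimated at 36%, range 16% to 58%.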

Compound 4, largest response reached (reported as percent of maximum), in percent of the reference or control that the assay uses: 69.9%
Compound 4: the middle estimate sits 33.9 percentage points below what was measured; measured number above the stated range.
By their numbers in this assay, from the lowest: compounds 1 and 3 (each within the scatter of the next); then compound 2; then compound 4.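

In this assay the hydroxy on the aromatic carbon matters with 3-carboxyphenyl in place: hydroxy in place of methyl gives a number 51.6 percentage points higher from compound 1 to compound 4 (beyond the scatter) as a large step. With that hydroxy kept, 3-carboxyphenyl in place of 4-carboxyphenyl gives a number 18 percentage points higher from compound 2 to compound 4 (beyond the scatter) and shows that the carboxy position also counts. The step from the ester, a number 47.2 percentage points higher from compound 3 to compound 4 (beyond the scatter), combines two changes, the free acid and its position.

Going by these compounds, whether an amide or a tetrazole can replace the carboxylic acid stays open, as does the effect of a shorter or longer chain. No measurement shown here explains these steps.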